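This account rests on a few compounds, and the source may have more. Where it says the series, first, only, none or still open, it means among the compounds named here.

Measured so far:
compound 1 `Cc1ccccc1-n1nc(C)c2c1NC(=O)[C@H](C)S[C@@H]2c1ccc(/C=C/c2ccccc2)cc1` gives "not active" (no number reported) in an assay on isolated protein for agonist activity at Bile acid receptor (Homo sapiens), read by AlphaScreen, with a stated time of 30 min; a higher number here means that more compound is needed for the effect, a lower number that less compound is needed
compound 2 `Cc1ccccc1-n1nc(C)c2c1NC(=O)[C@H](C)S[C@@H]2c1ccc(Oc2ccccc2)cc1` gives 1300 nM in this assay

Compound 2 holds the only number shown; compound 1 yielded no number at all. Compound 3 `Cc1ccccc1-n1nc(C)c2c1NC(=O)[C@H](C)S[C@@H]2c1ccc(Oc2ccccc2C(=O)O)cc1` differs from compound 2 by carboxy in place of hydrogen on an aromatic carbon. Among the compounds with values here, no step between measured compounds is available to set the scale, so the expectation rests on compound 2 alone. A moderate gain beyond the usual scatter is expected, the step of a 3.3-fold lower number from compound 2 to compound 3 (0.51 log units; beyond the scatter) pointing toward a lower half-maximal effective concentration. Compound 3 is accordingly estimated at 400 nM, within a range from 100 nM to 2000 nM.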

Compound 3, half-maximal effective concentration: "not active" (no number reported)
Nothing numeric was reported for compound 3; no gap can be computed for the estimate.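

Compound 3, like compound 1, gave no number, so no step from compound 2 to compound 3 can be read, and nothing shown accounts for the result. Going by these compounds, whether other groups in that place would give a number remains open.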